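From Oxolan-3-yl to Phenethyl on Compound 2

The source may hold more compounds than are shown below. What is called first, only, known or untested is meant among the compounds shown, and "the series" means these compounds.

Compound 1 `COc1ccc([C@H]2CC(=O)N(c3cccc(N(C)C)c3)C2)cc1OC1CCCC1` and compound 2 `COc1ccc([C@H]2CC(=O)N(c3cccc(NCC4CCOC4)c3)C2)cc1OC1CCCC1` share one core and differ only in the group on the aromatic nitrogen. In a functional assay on HEK293 cells (Homo sapiens) for cytotoxicity (on this read-out lower numbers stand for higher toxicity in this test and higher numbers for lower toxicity in this test), compound 1 gives > 10000 nM as a limit, not a number. Compound 2 gives > 10000 nM as well, again only a limit. Both compounds therefore stand at the limit of > 10000 nM in this assay, at which 2 of the 2 values shown sit, and offer no exact starting point. Compound 3 `COc1ccc([C@H]2CC(=O)N(c3cccc(NCCCc4ccccc4)c3)C2)cc1OC1CCCC1` differs from compound 2 by phenethyl in place of oxolan-3-yl on a saturated chain carbon bound to a nitrogen on an aromatic ring and so carries phenethyl in place of oxolan-3-yl on a saturated chain carbon bound to a nitrogen on an aromatic ring. Within the data shown here, the only measured evidence is a step that the two limits leave unreadable from compound 1 to compound 2 and gives no size to carry over. No clear direction can be expected, so the estimated change is a step that the limit leaves unreadable from compound 2 to compound 3 and another limit is the likeliest result. For compound 3 the expected value in this assay is 15000 nM within an estimated range of 6000 nM to 40000 nM for now.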

Compound 3, half-maximal cytotoxic concentration: > 10000 nM
Compound 3: only a limit was reported; the forecaster's own chance of this, stated with the estimate: 80%; the middle value does not contradict the limit.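

Compound 1, compound 2 and compound 3 each give only a limit, not a number, in this assay, so no step between them can be read: the limit of > 10000 nM in this assay, at which 3 of the 3 values shown sit.

As far as these compounds go, whether swapping these groups changes the result at all in this test stays open, since none of the three compounds has an exact value.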